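Pyrazole series, acetyl to dimethylamino exchange on the pendant phenyl

The compounds below may be only part of what the source reports. "The series", "measured", "known", "first", "only" and "open" are said of these compounds alone.

Measured so far in a functional assay on OVCAR-5 cells (Homo sapiens) for cytotoxicity, read by sulforhodamine B assay, with a stated time of 48 h, tested at 100 nM; a higher number here means a weaker effect of the compound at the concentration tested, a lower number a stronger effect:
compound 1 `COc1cc(C)cc(-c2c(-c3ccnc(-c4ccc(C(C)=O)cc4)c3)cnn2CC#N)c1`: 89%
compound 2 `Cc1cc(O)cc(-c2nn(CC#N)cc2-c2ccnc(-c3ccc(Oc4ccccc4)cc3)c2)c1`: 82%
compound 3 `COc1cc(C)cc(-c2nn(CC#N)cc2-c2ccnc(-c3ccc(N(C)C)cc3)c2)c1`: 79%

Compound 1 gives the highest of the three numbers in this assay . The nearest to it is compound 2, and the furthest is compound 3; both gaps fall within the usual scatter, so no order can be read among the three, and none of them can be called the stronger or the weaker. All three compounds leave most cells intact at the concentration tested.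

Compound 4 `COc1cc(C)cc(-c2c(-c3ccnc(-c4ccc(N(C)C)cc4)c3)cnn2CC#N)c1` has not yet been measured in this assay . It differs from compound 1 in one place: dimethylamino in place of acetyl on an aromatic carbon. For the measured compounds named here, no step between two measured compounds isolates this exchange, so there is no measured size to lean on. Compound 3 carries the same dimethylamino group on a differently built core and gives 79%, which sits with the others.

Given that the three measured numbers lie within the scatter of one another, the step from compound 1 to compound 4 is expected to be small, estimated as a number 5 percentage points lower from compound 1 to compound 4 (within the scatter), with no direction beyond the scatter. Compound 4 is therefore expected to give about 84%, in a range from 70% to 96%.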

Compound 4, a percentage reported as activity, at one concentration (the size of the read-out at that concentration, not a potency): 53%
The estimate for compound 4 lay 31 percentage points above the measured number, outside the stated range (below it).
By their numbers in this assay, from the lowest: compound 4; then compounds 3, 2 and 1 (each within the scatter of the next).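

In this assay, dimethylamino in place of acetyl on an aromatic carbon, para to a large group, gives a read-out that is a number 36 percentage points lower from compound 1 to compound 4 (beyond the scatter). This position therefore responds to the group it carries, which the three earlier numbers, all within the scatter of one another, could not show. Nothing available here bears on why the step has this size.

For the compounds shown here, a single exchange at this position leaves open whether the step belongs to the arrival of dimethylamino or to the departure of acetyl, and the read-out, taken at one concentration, gives no potency for either compound. A primary amine or a morpholine ring on the same aromatic carbon of the core of compound 1 would help to separate these two readings.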